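Trading an Acetyl Group for Hydrogen in a Small Series

A few compounds are considered here, and "the series" means these few. Any claim that something is new, unique, unknown or untested is made for them only; others in the source may bear on it.

Of the compounds shown here, two have been measured in a functional assay on cells (Monocyte, Homo sapiens) for inhibition; on this read-out lower numbers stand for stronger inhibition and higher numbers for weaker inhibition. Compound 1 `CCC[C@@H](OC(C)=O)C1=C(Br)/C(=C/Br)OC1=O` gives 1300 nM, and compound 2 `CCCCC1=C(Br)C(=C(Br)Br)OC1=O` gives 1800 nM. Compound 1 has the lower of the two numbers, but the two values lie within the scatter of each other, so neither compound can be called the stronger inhibitor. Within the data shown here, no pair of compounds that differ in only one place has been measured, so no step size is known from these data.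

Compound 3 `CCC[C@@H](O)C1=C(Br)/C(=C/Br)OC1=O` has not yet been measured. It differs from compound 1 in one place: hydrogen in place of acetyl on an oxygen on a saturated carbon. Nothing in the measured compounds shows what this change does to inhibition, so no step beyond the scatter is expected in either direction. The step of no change at the digits printed from compound 1 to compound 3 (within the scatter) is expected to be small. Compound 3 is therefore estimated to give about the same value as compound 1. The estimate for compound 3 is 1300 nM, expected to fall between 600 nM and 3000 nM.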

Compound 3, half-maximal inhibitory concentration: 600 nM
The estimate for compound 3 lay 2.2-fold (0.34 log units) above the measured number; the measured number falls inside the stated range.
By their numbers in this assay, from the lowest: compound 3; then compounds 1 and 2 (each within the scatter of the next).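

Among these compounds, replacing the acetyl with hydrogen, which turns acetoxy into hydroxy on the saturated carbon, gives a 2.2-fold lower number from compound 1 to compound 3 (0.34 log units; beyond the scatter) in this assay and so provides the first single-place change with a measured size. The step is modest but beyond the scatter, so at this oxygen in this pair, the acetyl is not needed for inhibition, and the free hydroxy compound 3 is the stronger inhibitor of the two. No measurement shown here bears on why the number falls.

This is a single pair on a single core, so it cannot show whether removing an acetyl would have the same effect on any other compound. It also leaves open what other groups on this oxygen would do: a methyl, which would give a methyl ether, or a longer ester such as butyryl could tell whether the trend follows the size of the group, while an amine in place of the hydroxy would test whether the oxygen itself matters.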